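The source may hold more compounds than are shown below. What is called first, only, known or untested is meant among the compounds shown, and "the series" means these compounds.

Working notes on the series. In a functional assay on MIA PaCa-2 cells (Homo sapiens) for inhibition, read by MTT assay, with a stated time of 3 days (a higher number here means a weaker inhibitor, a lower number a stronger inhibitor), compound 1 `CCN(CC)S(=O)(=O)c1ccc(S(=O)(=O)N2CCC[C@@H](C(=O)N3CCN(c4nc(C(F)(F)F)no4)CC3)C2)cc1` gives > 10000 nM, which is a limit of the assay rather than a number. Compound 2 `CCOC(=O)[C@@H]1CCCN(S(=O)(=O)c2cccc(S(=O)(=O)N(CC)CC)c2)C1` gives > 10000 nM in this assay, again a limit. Compound 3 `CCOC(=O)[C@@H]1CCCN(S(=O)(=O)c2ccc(S(=O)(=O)N(CC)CC)cc2C)C1` likewise gives only a limit, > 10000 nM. Where compound 1 stands is therefore told only by the limit of > 10000 nM in this assay, at which 3 of the 3 values shown sit; none of the three compounds carries a measured number, and no pair among them differs in a single place, so no step inside the measured set can be sized.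

Compound 4 `CCN(CC)S(=O)(=O)c1ccc(S(=O)(=O)N2CCC[C@@H](C(=O)N3CCN(C(=O)OC(C)(C)C)CC3)C2)cc1` is to be measured in this assay. It differs from compound 1 by tert-butoxycarbonyl in place of 3-(trifluoromethyl)-1,2,4-oxadiazol-5-yl on an amine nitrogen in a ring. Among the compounds with values here, with every measured value sitting at the limit, there is no measured step to lean on. The expected step that the limit leaves unreadable from compound 1 to compound 4 is none beyond the scatter, because compound 1 is known only through (the limit of > 10000 nM in this assay, at which 3 of the 3 values shown sit). Compound 4 is estimated at 15000 nM, with a range from 5000 nM to 50000 nM, and is most likely to be reported again only as a limit.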

Compound 4, half-maximal inhibitory concentration: > 10000 nM
Compound 4: only a limit was reported; the forecaster's own chance of this, stated with the estimate: 80%; the middle value lies beyond the limit too.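

No step can be read from compound 1 to compound 4, since both are known only as limits in this assay: the limit of > 10000 nM in this assay, at which 4 of the 4 values shown sit.

The compounds shown leave open which change to the shared core, if any, would bring a measured number rather than a limit.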